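This account rests on a few compounds, and the source may have more. Where it says the series, first, only, none or still open, it means among the compounds named here.

Compound 1 `COc1ccc(-c2ccc(OC(F)(F)F)c(NC(=O)Nc3ccncc3)c2)cn1` and compound 3 `COc1ccc(-c2ccc(OC(F)(F)F)c(NC(=O)Nc3nccs3)c2)cn1` share a core but differ in the group on the amide-type nitrogen: 1,3-thiazol-2-yl in place of pyridin-4-yl on an amide-type nitrogen. In a functional assay on A549 cells (Homo sapiens) for inhibition, read by MTT assay, with a stated time of 48 h (a lower number here means a stronger inhibitor, a higher number a weaker inhibitor), compound 1 gives only a limit, > 300000 nM. Compound 3 gives 35000 nM in this assay, so the step of an at least 8.5-fold lower number from compound 1 to compound 3 (0.93 log units; beyond the scatter) is read against that limit (the limit of > 300000 nM in this assay, at which 1 of the 3 values shown sits). Compound 2 `O=C(Nc1ccncc1)Nc1cc(-c2cncnc2)ccc1OC(F)(F)F` carries the other change on the core of compound 1, (pyrimidin-5-yl in place of 6-methoxypyridin-3-yl on an aromatic carbon). In this assay compound 2 gives 3750 nM, a step of an at least 80-fold lower number from compound 1 to compound 2 (1.90 log units; beyond the scatter). Compound 4 `O=C(Nc1nccs1)Nc1cc(-c2cncnc2)ccc1OC(F)(F)F`, not yet measured, applies the same kind of change to compound 3: pyrimidin-5-yl in place of 6-methoxypyridin-3-yl on an aromatic carbon. The surroundings are not identical, since the first change is described as meta to a large group while this one is meta to a ((1,3-thiazol-2-yl)carbamoyl)amino group. Going by these compounds, the step from compound 3 to compound 4 is expected to be a 23-fold lower number from compound 3 to compound 4 (1.37 log units; beyond the scatter), resting on the step of an at least 80-fold lower number from compound 1 to compound 2 (1.90 log units; beyond the scatter), though that step starts from a limit and its true size is unknown. Compound 4 is expected to give about 1500 nM in this assay, between 300 nM and 8000 nM.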

Compound 4, half-maximal inhibitory concentration: 17600 nM
Estimate against measurement, compound 4: 12-fold (1.07 log units) below; measured number above the stated range.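

On the core of compound 3, the change to pyrimidin-5-yl from 6-methoxypyridin-3-yl gives a 2.0-fold lower number from compound 3 to compound 4 (0.30 log units; within the scatter) in this assay, so the large step seen on the core of compound 1 does not carry over to this core: the same change on two cores in this assay, an at least 80-fold lower number (1.90 log units; beyond the scatter) from compound 1 to compound 2 and a 2.0-fold lower number (0.30 log units; within the scatter) from compound 3 to compound 4, at least 40-fold (1.60 log units) apart, beyond the scatter of two such steps. The other change, 1,3-thiazol-2-yl in place of pyridin-4-yl, gives a 4.7-fold higher number from compound 2 to compound 4 (0.67 log units; beyond the scatter), which runs in the opposite direction to the step it gave on the core of compound 1: the same change on two cores in this assay, an at least 8.5-fold lower number (0.93 log units; beyond the scatter) from compound 1 to compound 3 and a 4.7-fold higher number (0.67 log units; beyond the scatter) from compound 2 to compound 4, at least 40-fold (1.60 log units) apart, beyond the scatter of two such steps. Compound 1, the starting point of both earlier steps, gives only a limit, so the gaps are known only as minimum sizes, and the four compounds show that the outcome of each change depends on the other group but not why: the limit of > 300000 nM in this assay, at which 1 of the 4 values shown sits.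

Going by these compounds, it remains open whether a phenyl ring or a pyridin-3-yl group in the place of pyrimidin-5-yl would behave alike on both cores. Also open, on these data alone, is whether this dependence would persist with a methoxy group in place of the trifluoromethoxy group.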